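This account rests on a few compounds, and the source may have more. Where it says the series, first, only, none or still open, it means among the compounds named here.

Compound 1 `CCC(CC)c1ccc2c(NCCCNCc3cccc(OC)c3O)ccnc2c1` is the poorest dissolving of the three compounds measured in a physicochemical assay for solubility, with a stated time of 18 h, at pH 7.4; on this read-out lower numbers stand for lower solubility and higher numbers for higher solubility: compound 1 gives 4200 nM, while compound 2 `FC(F)(F)c1ccc(-c2ccc3c(NCCCNCc4ccco4)ccnc3c2)cc1` gives 32000 nM and compound 3 `c1coc(CNCCCNc2ccnc3cc(-c4cccc5ccccc45)ccc23)c1` gives 32000 nM, each beyond the scatter away from compound 1. Going by the values given here, the one single-point step among the measured compounds, no change at the digits printed from compound 2 to compound 3 (within the scatter), concerns an exchange of one aryl group for another and leaves the reading unmoved.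

Compound 4 `COc1cccc(CNCCCNc2ccnc3cc(CC4CCCCC4)ccc23)c1O` differs from compound 1 in another way: cyclohexylmethyl in place of pentan-3-yl on an aromatic carbon. Among the compounds with values here, no measured step involves an alkyl group of this kind, so the aryl exchange from compound 2 to compound 3 gives only indirect guidance that a modest change at this position need not shift this assay much. With nothing pointing to a shift beyond the scatter in either direction, compound 4 is expected to stay close to compound 1, with the step of a 1.2-fold lower number from compound 1 to compound 4 (0.08 log units; within the scatter) judged small. Compound 4 is therefore estimated at 3500 nM, within a range of 1200 nM to 10000 nM.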

Compound 4, solubility: 4200 nM
The estimate for compound 4 lay 1.2-fold (0.08 log units) below the measured number; the range from low to high includes it.
By their numbers in this assay, from the lowest: compounds 1 and 4 (each within the scatter of the next); then compounds 2 and 3 (each within the scatter of the next).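

Replacing pentan-3-yl with cyclohexylmethyl on this aromatic carbon gives no change at the digits printed from compound 1 to compound 4 (within the scatter) in this assay. Going by these compounds alone, the only earlier step exchanged one aryl group for another, whereas this one shows that the reading of compound 4 also stays within the scatter of compound 1 when one non-aromatic carbon group replaces another, even with a six-membered non-aromatic ring entering and the carbon count of the group changing. No accompanying measurement offers an explanation for this result. The compounds shown leave open whether a group bearing an amine or a carboxylic acid on this aromatic carbon would keep the reading in this assay where it stands for compound 1. They also leave open whether a longer alkyl chain or a methoxy group there would do so.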